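The source may hold more compounds than are shown below. What is called first, only, known or untested is meant among the compounds shown, and "the series" means these compounds.

Three compounds sharing the core of compound 1 `O=C(Nc1ccccc1)C(Cl)Cl` were examined in a functional assay on KB cells (Homo sapiens) for antiproliferative activity, read by MTT assay, with a stated time of 72 h; a higher number here means a weaker inhibitor, a lower number a stronger inhibitor; for compound 1 itself the result is "not determined" (no result reported). Compound 2 `O=C(Nc1cccc(I)c1)C(Cl)Cl` gives 5250 nM, and compound 3 `O=C(Nc1cccc(C(F)(F)F)c1)C(Cl)Cl` gives 8860 nM. Of these two numbers compound 3 holds the higher one, yet the step of a 1.7-fold higher number from compound 2 to compound 3 (0.23 log units; within the scatter) lies within the scatter, so on these data the two compounds cannot be told apart. Compound 4 `O=C(Nc1cccc(OC(F)(F)F)c1)C(Cl)Cl` has not been measured. It differs from compound 3 in one place: trifluoromethoxy in place of trifluoromethyl on an aromatic carbon. Among the compounds with values here, no measured step swaps exactly these two groups. Within the data shown here, the only step available, a 1.7-fold higher number from compound 2 to compound 3 (0.23 log units; within the scatter), shows that replacing one group at this aromatic carbon with another moved the number only within the scatter, and that is the sole guide here. The expected change from compound 3 to compound 4 is therefore a step of a 1.1-fold lower number from compound 3 to compound 4 (0.04 log units; within the scatter), with no direction claimed beyond the scatter. Compound 4 is estimated at 8000 nM, within a range from 3000 nM to 20000 nM.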

Compound 4, half-maximal inhibitory concentration: 7410 nM
The estimate for compound 4 lay 1.1-fold (0.03 log units) above the measured number, within the range that was stated.
By their numbers in this assay, from the lowest: compounds 2, 4 and 3 (each within the scatter of the next).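

In this assay a third group at this aromatic carbon now stands beside iodo and trifluoromethyl. The step from trifluoromethyl to trifluoromethoxy (a 1.2-fold lower number from compound 3 to compound 4 (0.08 log units; within the scatter)) and the step from iodo to trifluoromethoxy (a 1.4-fold higher number from compound 2 to compound 4 (0.15 log units; within the scatter)) both stay within the scatter, so inserting an oxygen into the trifluoromethyl group produced no readable difference, and compounds 2, 3 and 4 cannot be told apart. No measurement shown here bears on why these three groups read alike.

Any step from compound 1, which has no group at this carbon, cannot be read, as compound 1 gives "not determined" (no result reported), so what these groups add over the unsubstituted ring stays unknown. Going by these compounds, whether an amine, a carboxylic acid or a longer carbon chain at this carbon would shift the number beyond the scatter also remains open.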